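From Compound 2 to Compound 3: One Methyl Fewer

The source may hold more compounds than are shown below. What is called first, only, known or untested is meant among the compounds shown, and "the series" means these compounds.

In an ADME assay on HepG2 cells (Homo sapiens) for cytotoxicity, read by MTT assay, with a stated time of 24 h (on this read-out lower numbers stand for higher toxicity in this test and higher numbers for lower toxicity in this test), compound 1 `CC1Cn2cc([N+](=O)[O-])nc2O1` gives > 500000 nM, which is a limit of the assay and not a number. Compound 2 `Cc1ccc(-c2c([N+](=O)[O-])nc3n2CC(C)O3)cc1` gives > 125000 nM, which is also only a limit. Compound 2 therefore stands on a limit, as does compound 1, and the two have no numbers to compare. Compound 3 `CC1Cn2c(nc([N+](=O)[O-])c2-c2ccccc2)O1` has hydrogen in place of methyl on an aromatic carbon. For the measured compounds named here, no measured step shows the effect of this change, so no shift beyond the scatter is expected in this assay. The expected step is a step that the limit leaves unreadable from compound 2 to compound 3. For compound 3, the estimated value is 150000 nM, within an expected range of 80000 nM to 400000 nM.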

Compound 3, half-maximal cytotoxic concentration: > 500000 nM
Compound 3 ended at the assay's limit (the forecaster's own chance of this, stated with the estimate: 80%); at least 3.3-fold (0.52 log units) between middle value and limit.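

Compound 1, compound 2 and compound 3 all stand on limits in this assay, so no new step can be read. The compounds shown leave open whether swapping methyl for hydrogen or adding phenyl changes the read-out at all.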